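Swapping Ethoxymethyl for Phenyl: Expected Cytotoxicity of Compound 3

A few compounds are considered here, and "the series" means these few. Any claim that something is new, unique, unknown or untested is made for them only; others in the source may bear on it.

The account begins with compound 1 `CCOCCOC(=O)Nc1cc2nc(C3CCCCC3)[nH]c2cc1N(C)C`. In an ADME assay on Vero cells (Chlorocebus sabaeus) for cytotoxicity, read by resazurin assay, with a stated time of 3 days (on this read-out higher numbers stand for weaker inhibition and lower numbers for stronger inhibition), compound 1 gives > 100 ug/mL, which is a limit of the assay rather than a number. A second compound, compound 2 `CCCCOC(=O)Nc1cc2nc(C3CCCCC3)[nH]c2cc1N(CCC)CCC`, shares the core. In this assay compound 2 gives > 100 ug/mL, again a limit. Compound 1 therefore stands at the limit shared by both values shown, as summarised by the limit of > 100 ug/mL in this assay, at which 2 of the 2 values shown sit, so its true position is known only as a bound.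

Compound 3 `CN(C)c1cc2[nH]c(C3CCCCC3)nc2cc1NC(=O)OCc1ccccc1` differs from compound 1 by phenyl in place of ethoxymethyl on a saturated chain carbon bound to an oxygen next to a carbonyl group. Going by the values given here, no measured pair shows the effect of such a change, and both known values sit at the same bound, so the author expects no step beyond the usual scatter for a number no higher from compound 1 to compound 3 (the limit leaves the size open). For compound 3 the estimated value in this assay is 100 ug/mL, within a range from 50 ug/mL to 200 ug/mL, most likely reported again as a limit.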

Compound 3, half-maximal inhibitory concentration: > 100 ug/mL
Compound 3 was reported as a limit; the forecaster's own chance of this, stated with the estimate: 70%; the middle value lies on the limit itself.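

Compound 3 gives > 100 ug/mL in this assay as a limit of the assay. No step can be read between compound 1 and compound 3, since both stand at a limit. The compounds shown leave open how far each true value lies beyond that limit, and whether phenyl in place of ethoxymethyl changes it at all: the limit of > 100 ug/mL in this assay, at which 3 of the 3 values shown sit.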